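The source may hold more compounds than are shown below. What is called first, only, known or untested is meant among the compounds shown, and "the series" means these compounds.

Compound 2, `CC(C)c1ccccc1NC(=O)N[C@H](C)c1ccccc1`, and compound 1, `CCc1ccccc1NC(=O)N[C@H](C)c1ccccc1`, share the same core and differ only in one group on an aromatic ring. In an ADME assay on the whole organism with Oryza sativa as the target, tested at 0.1 uM (on this read-out higher numbers stand for a weaker effect at the one concentration tested and lower numbers for a stronger effect), compound 1 gives 101%, and compound 2 gives 103%; the two numbers lie within the usual scatter of each other, so neither compound shows a clear effect at the single concentration tested. Among the compounds with values here, the only measured step, a number 2 percentage points higher from compound 1 to compound 2 (within the scatter), therefore points to no change in this read-out. Compound 3, `C[C@@H](NC(=O)Nc1ccccc1C(F)(F)F)c1ccccc1`, carries trifluoromethyl in place of isopropyl on an aromatic carbon. Within the data shown here, no measured step exchanges one group for another of a different kind in this way, so the evidence is thin; the one step in hand stayed within the scatter, and both measured compounds sit near the point of no effect. The expectation for compound 3 is thus a step of a number 3 percentage points lower from compound 2 to compound 3 (within the scatter), none beyond the scatter. Compound 3 is estimated at 100% in this assay, with a range from 86% to 114%.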

Compound 3, a percentage reported as activity, at one concentration (the size of the read-out at that concentration, not a potency): 99%
Compound 3: the middle estimate sits 1 percentage points above what was measured, within the range that was stated.
By their numbers in this assay, from the lowest: compounds 3, 1 and 2 (each within the scatter of the next).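

Trifluoromethyl in place of isopropyl gives a number 4 percentage points lower from compound 2 to compound 3 (within the scatter) in this assay, and trifluoromethyl in place of ethyl gives a number 2 percentage points lower from compound 1 to compound 3 (within the scatter). This position, on an aromatic carbon ortho to a large group, has now carried three different groups, one of them holding fluorine rather than only carbon and hydrogen, and no step among the compounds shown goes beyond the scatter. Nothing measured alongside these numbers offers a reason for this flat picture.

Still open, as far as these compounds go, is whether any group at this position can move the read-out beyond the scatter, such as an amine, a carboxylic acid or a longer chain. The single concentration also leaves open whether these three compounds would differ at a higher one.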